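The compounds below may be only part of what the source reports. "The series", "measured", "known", "first", "only" and "open" are said of these compounds alone.

Compound 1 `COc1cc(-c2cccc3nc(-c4cccc(F)c4)oc23)cc(OC)c1OC`: 2900 nM
Compound 2 `COc1cc(-c2cccc3nc(-c4ccc(F)cc4)oc23)cc(OC)c1OC`: > 25000 nM

Both compounds were tested in a functional assay on U-251 cells (Homo sapiens) for antiproliferative activity, read by MTT assay, with a stated time of 48 h; a higher number here means a weaker inhibitor, a lower number a stronger inhibitor. Compound 2 stands at > 25000 nM, which is a limit and not a number. It is thus (the limit of > 25000 nM in this assay, at which 1 of the 2 values shown sits).

Compound 3 `COc1cc(-c2cccc3nc(-c4cccc(Cl)c4)oc23)cc(OC)c1OC` carries 3-chlorophenyl in place of 4-fluorophenyl on an aromatic carbon of a five-membered aromatic ring with 1 nitrogen and 1 oxygen, part of a fused or bridged system of two rings. The counted difference is 3-chlorophenyl in place of 4-fluorophenyl on an aromatic carbon.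

Among the measured compounds shown here, one measured step bears on this change. It is an at least 8.6-fold higher number from compound 1 to compound 2 (0.93 log units; beyond the scatter), beyond the scatter, and it came with 4-fluorophenyl in place of 3-fluorophenyl. Compound 3 gives up the 4-fluorophenyl of compound 2 for a 3-substituted group again, so much of that step is expected to reverse. The closest guide is compound 1, with 3-fluorophenyl and 2900 nM. For the measured compounds named here, no measured step covers chlorine in place of fluorine, so the range stays wide.

In this assay the expected change is an at least 7.1-fold lower number from compound 2 to compound 3 (0.85 log units; beyond the scatter), towards stronger inhibition. For compound 3 the estimate is 3500 nM, with an expected range from 1000 nM to 12000 nM.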

Compound 3, half-maximal inhibitory concentration: 18500 nM
For compound 3 the middle estimate is 5.3-fold (0.72 log units) below the measured one, and the stated range ends below it.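

In this assay, the result shows that a 3-substituted phenyl group on this carbon does not by itself keep the activity of compound 1, as the halogen on that ring also counts: a 6.4-fold higher number from compound 1 to compound 3 (0.80 log units; beyond the scatter). Chloro in place of fluoro is thus a change that the assay can see, and compound 1 remains the stronger of this pair. Against the 4-fluorophenyl group, the comparison gives an at least 1.3-fold lower number from compound 2 to compound 3 (0.13 log units; that floor lies within the scatter), and since that floor lies within the scatter, it does not establish that 3-chlorophenyl is any better than 4-fluorophenyl; compound 2 has a limit and not a number: the limit of > 25000 nM in this assay, at which 1 of the 3 values shown sits.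

The compounds shown leave open whether the loss from fluoro to chloro continues with 3-bromophenyl, or whether it is tied to halogens at all, which 3-methylphenyl or 3-methoxyphenyl could test. They also leave open whether 4-chlorophenyl, or the plain unsubstituted phenyl group, would stand closer to compound 1 or to compound 3, and they do not tell why chloro and fluoro differ here.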